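The source may hold more compounds than are shown below. What is called first, only, known or untested is meant among the compounds shown, and "the series" means these compounds.

Compound 1 `COc1cc(-c2cc(=O)c3cc(O)ccc3o2)cc(OC)c1OC` is the reference point. In a functional assay on A549 cells (Homo sapiens) for cytotoxicity, read by MTT assay, with a stated time of 6 days (a lower number here means that less compound is needed, a higher number that more compound is needed for the effect), compound 1 gives 9.82 ug/mL. Compound 3 `COc1cc(-c2cc(=O)c3cc(O)ccc3o2)cc(OC)c1O[Si](C)(C)C(C)(C)C` carries a group of 7 heavy atoms (6 carbon, 1 silicon; no ring) in place of one carbon atom, on an oxygen on an aromatic ring, and in this assay compound 3 gives 3.19 ug/mL, which is a 3.1-fold lower number from compound 1 to compound 3 (0.49 log units; beyond the scatter). Compound 2 `COc1cc(-c2cc(=O)c3ccc(O)cc3o2)cc(OC)c1OC` is built from the same atoms joined differently; the difference between the two cores is not broken down here. In this assay compound 2 reaches only a limit of the measurement, > 25 ug/mL, as recorded in the limit of > 25 ug/mL in this assay, at which 1 of the 3 values shown sits. Compound 4 `COc1cc(-c2cc(=O)c3ccc(O)cc3o2)cc(OC)c1O[Si](C)(C)C(C)(C)C` has not been measured yet; relative to compound 2 it carries the same change, (a group of 7 heavy atoms (6 carbon, 1 silicon; no ring) in place of one carbon atom, on an oxygen on an aromatic ring), at a place described in the same words. A step of similar size is expected, an at least 1.6-fold lower number from compound 2 to compound 4 (0.22 log units; that floor lies within the scatter), by analogy with the step of a 3.1-fold lower number from compound 1 to compound 3 (0.49 log units; beyond the scatter). The starting value of compound 2 is known only as a limit. For compound 4 a value near 15 ug/mL is expected, most likely between 6 ug/mL and 40 ug/mL, with a real chance that only a limit is reported.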

Compound 4, concentration for half-maximal effect: 5.3 ug/mL
Beside the measured number, compound 4's estimate is 2.8-fold (0.45 log units) above it; the measured number lies below the stated range.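

In this assay, replacing the methyl on the aromatic oxygen with the group of 7 heavy atoms (6 carbon, 1 silicon) means less compound is needed on both cores, and the second core gives an at least 4.7-fold lower number from compound 2 to compound 4 (0.67 log units; beyond the scatter). The entry for compound 2 is a limit of the assay and not a number: > 25 ug/mL. The change therefore carries over in direction between these two cores, but the data do not show whether its size is the same: the same change on two cores in this assay, a 3.1-fold lower number (0.49 log units; beyond the scatter) from compound 1 to compound 3 and an at least 4.7-fold lower number (0.67 log units; beyond the scatter) from compound 2 to compound 4; the limit leaves it open whether they differ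

The compounds shown leave open how a plain longer chain, such as butyl, or a chain ending in an amine would behave on that oxygen. They also leave open whether the same step would appear on any further core.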